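Naphthalene for Thiophene on a Fused Dioxane Core

This account rests on a few compounds, and the source may have more. Where it says the series, first, only, none or still open, it means among the compounds named here.

Measured compounds:
Compound 1 `O=[N+]([O-])c1ccc([C@@H]2OC[C@H]3O[C@@H](c4ccccc4)[C@H](O)[C@@H](O)[C@@H]3O2)cc1` gives 50 ug/mL in a functional assay on HEL cells (Homo sapiens) for cytotoxicity; a lower number here means that less compound is tolerated, a higher number that more compound is tolerated.
Compound 2 `CO[C@@H]1[C@@H](OC)[C@H](c2ccccc2)O[C@@H]2CO[C@@H](c3cccs3)O[C@@H]12` gives "not determined" (no result reported) in this assay, that is, no result was reported for it.

Compound 2 therefore stands nowhere on the numbers shown: its tolerated concentration in this assay was not determined, so nothing can be said of how it compares with compound 1, which shares only part of its core and carries different substituents.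

Compound 3 `CO[C@@H]1[C@@H](OC)[C@H](c2ccccc2)O[C@@H]2CO[C@@H](c3ccc4ccccc4c3)O[C@@H]12` is the next compound in line. It differs from compound 2 in one place: naphthalen-2-yl in place of thiophen-2-yl on a saturated ring carbon.

Among the measured compounds shown here, with no step between measured compounds to lean on, the expected size of this change in this assay is uncertain. The exchange of a five-membered heteroaromatic ring for a fused pair of six-membered carbon rings is a sizeable alteration, so a shift beyond the usual scatter is plausible, and the direction guessed is toward less compound tolerated, though a result within the scatter cannot be excluded.

Compound 3 is estimated at 30 ug/mL in this assay, with a range from 10 ug/mL to 100 ug/mL.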

Compound 3, minimum cytotoxic concentration: >= 16 ug/mL
Compound 3 was reported as a limit; the forecaster's own chance of this, stated with the estimate: 25%; the middle value lies beyond the limit too.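

No step can be read from compound 2 to compound 3, because compound 2 carries no number and compound 3 is reported only as a limit: the limit of >= 16 ug/mL in this assay, at which 1 of the 3 values shown sits.

The compounds shown leave open how much, and in which direction, the exchange of thiophen-2-yl for naphthalen-2-yl moves the result in this assay on this shared core.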